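Moving the carboxy group on the far aryl ring of compound 2

The compounds below may be only part of what the source reports. "The series", "measured", "known", "first", "only" and "open" are said of these compounds alone.

In an assay on HEK293 cells for positive allosteric modulation of metabotropic glutamate receptor 2 (Rattus norvegicus), read by thallium flux, with a stated time of 2.5 min (a higher number here means a larger maximal response, a lower number a smaller maximal response), compound 2 `Cc1c(OCCCCOc2ccccc2C(=O)O)ccc(C(=O)CC2CCCC2)c1O` gives 98.8%, the highest of the three numbers measured. Compound 1 `Cc1c(OCCCCOc2ccccc2C(=O)O)ccc(C(=O)CC2CCCC2)c1C` gives 67.1% in this assay, and compound 3 `Cc1c(OCCCCOc2cccc(C(=O)O)c2)ccc(C(=O)CC(C)C)c1C` gives 12.1%. Going by the values given here, the one step measured in a single place is a number 31.7 percentage points higher from compound 1 to compound 2 (beyond the scatter), which means compound 2 stands well above compound 1.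

Compound 4 `Cc1ccc(C(=O)O)cc1OCCCCOc1ccc(C(=O)CC2CCCC2)c(O)c1C` has not yet been measured. It differs from compound 2 in one place: 5-carboxy-2-methylphenyl in place of 2-carboxyphenyl on an oxygen on a saturated carbon. Among the compounds with values here, no measured step bears directly on this change. The step from compound 1 to compound 2 concerns the hydroxy group, which compound 4 keeps, so it says nothing about the carboxy position. Compound 3 carries its carboxy group at a different position from compound 2 and gives a far smaller response, but compound 3 also differs from compound 2 in the hydroxy group and in the ketone side chain, so its low number cannot be assigned to the carboxy position alone.

The author therefore expects compound 4 to give a lower maximal response than compound 2, with a step estimated as a number 48.8 percentage points lower from compound 2 to compound 4 (beyond the scatter), but with wide uncertainty. For compound 4 the estimate in this assay is 50%, with a range from 15% to 90%.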

Compound 4, largest response reached (reported as percent of maximum), in percent of the reference or control that the assay uses: 67.5%
Compound 4: middle estimate off by 17.5 percentage points, on the low side; low and high end bracket the measured number.
By their numbers in this assay, from the lowest: compound 3; then compounds 1 and 4 (each within the scatter of the next); then compound 2.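

Going by these compounds alone, the far aryl ring proves not to be a silent part of the molecule: in this assay, the swap of 2-carboxyphenyl for 5-carboxy-2-methylphenyl gives a number 31.3 percentage points lower from compound 2 to compound 4 (beyond the scatter), the first measured change at this place with the hydroxy group and the cyclopentyl ketone side chain held constant. The response is reduced but not lost, since compound 4 still gives 67.5%, so this place tolerates the new group while still affecting how large a maximal response is reached. The step nevertheless joins two differences, a moved carboxy group and an added methyl, and nothing given here, neither a measured property nor any other evidence, accounts for its size.

The compounds shown leave open how much of the step belongs to the carboxy position and how much to the methyl, and whether the same swap would have a similar size on the core of compound 1, which carries methyl in place of hydroxy. They also leave open what a tetrazole or a primary amide would give in place of the carboxylic acid on this ring.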